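The source may report more compounds than this note shows. Statements on the series, on what has been measured and on what is new or still open speak of the compounds shown alone.

Of the compounds shown here, three from this series have been measured. Compound 1 `O=C(O)CCC(=O)N(C1CC1)C1c2ccccc2N(C(=O)OCc2ccccc2)C2CCC21` gives 25 nM in an assay on cells for displacement of a labelled ligand from prostaglandin D2 receptor 2 (Homo sapiens), read by scintillation counting, with a stated time of 60 min; on this read-out higher numbers stand for weaker inhibition and lower numbers for stronger inhibition. Compound 2 `O=C(O)CCC(=O)N(C1CC1)[C@H]1c2ccccc2N(C(=O)c2cccc(OC(F)(F)F)c2)[C@H]2CC[C@H]21` gives 5 nM in this assay, and compound 3 `O=C(O)COC(=O)N(C1CC1)[C@H]1c2ccccc2N(C(=O)c2cccc(F)c2)[C@H]2CC[C@H]21` gives 4.1 nM in this assay. Among these numbers, compound 3 sits at the low end: its value lies within the scatter of that of compound 2, while the number for compound 1 stands well beyond the scatter above it.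

The next compound, compound 4 `O=C(O)COC(=O)N(C1CC1)[C@H]1c2ccccc2N(C(=O)c2ccc(F)cc2)[C@H]2CC[C@H]21`, keeps the same atoms as compound 3 but joins them differently: 4-fluorophenyl in place of 3-fluorophenyl on a carbonyl carbon. Within the data shown here, no measured pair in this set shows what such a change does on its own, so there is nothing here to point toward either a gain or a loss. The expectation is therefore a step from compound 3 to compound 4 of about a 1.5-fold higher number from compound 3 to compound 4 (0.17 log units; within the scatter), that is, none beyond the scatter. On that basis compound 4 is estimated at 6 nM in this assay, with a range from 2 nM to 18 nM.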

Compound 4, inhibition constant: 3.5 nM
The estimate for compound 4 lay 1.7-fold (0.23 log units) above the measured number; low and high end bracket the measured number.
By their numbers in this assay, from the lowest: compounds 4, 3 and 2 (each within the scatter of the next); then compound 1.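

Replacing 3-fluorophenyl with 4-fluorophenyl on a carbonyl carbon whose other neighbour is an amide-type nitrogen in a ring gives a 1.2-fold lower number from compound 3 to compound 4 (0.07 log units; within the scatter) in this assay. Among these compounds, this is the first step between compounds that differ in one place, and it shows that this read-out does not separate these two fluorophenyl groups at this position. Nothing available here bears on why the two groups read alike.

As far as these compounds go, what remains open is how this position responds to a different group altogether, such as a phenyl without fluorine, a pyridine or a cyclohexyl. From the compounds shown here alone, it is also open whether the same exchange of fluorophenyl groups would read alike with another chain on the shared core, such as the acid chain of compound 2.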